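A few compounds are considered here, and "the series" means these few. Any claim that something is new, unique, unknown or untested is made for them only; others in the source may bear on it.

Of the compounds shown here, three built on one shared core have been tested for how strongly they hurt cultured human lung-derived cells. For compound 1 `COc1ccc(OC)c(/C=N/NC(=O)Nc2ccc(Oc3ccnc(-c4nncn4CCN(C)C)c3)c(F)c2)c1` the result in an ADME assay on WI-38 cells (Homo sapiens) for cytotoxicity, read by MTT assay, with a stated time of 72 h (a higher number here means a weaker inhibitor, a lower number a stronger inhibitor), is "not determined" (no result reported). Compound 2 `Cc1cc(/C=N/NC(=O)Nc2ccc(Oc3ccnc(-c4nncn4CCN(C)C)c3)c(F)c2)cc(C)c1O` gives 3610 nM in this assay. Compound 3 `COc1ccc(/C=N/NC(=O)Nc2ccc(Oc3ccnc(-c4nncn4CCN(C)C)c3)c(F)c2)c(OC)c1` gives 6630 nM in this assay, which is the higher of the two numbers available, though the step of a 1.8-fold higher number from compound 2 to compound 3 (0.26 log units; within the scatter) lies within the scatter of repeated measurements, so the two compounds cannot be ranked against each other.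

Compound 4 `CN(C)CCn1cnnc1-c1cc(Oc2ccc(NC(=O)N/N=C/c3c(Cl)cccc3Cl)cc2F)ccn1` is the next member. Compared with compound 3 it differs in one place: 2,6-dichlorophenyl in place of 2,4-dimethoxyphenyl on a carbon with a double bond to nitrogen. Among the compounds with values here, the only measured step, from one aryl group to another on the same carbon with a double bond to nitrogen, was within the scatter. Within the data shown here, no measured pair shows what a 2,6-dichlorophenyl does at that position, so the expectation rests on that single small step alone. Compound 4 is therefore expected to sit close to compound 3, with a step of a 1.1-fold lower number from compound 3 to compound 4 (0.04 log units; within the scatter) that need not exceed the scatter. The estimate for compound 4 in this assay is 6000 nM, with a likely range from 2500 nM to 15000 nM.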

Compound 4, half-maximal inhibitory concentration: 3320 nM
Compound 4: the middle estimate sits 1.8-fold (0.26 log units) above what was measured, and the stated range covers the measured number.
By their numbers in this assay, from the lowest: compounds 4, 2 and 3 (each within the scatter of the next).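

In this assay the step of a 2.0-fold lower number from compound 3 to compound 4 (0.30 log units; within the scatter) and the step of a 1.1-fold lower number from compound 2 to compound 4 (0.04 log units; within the scatter) both lie within the scatter, so the three numbers now available cannot be ranked against one another. The earlier pair had only shown two aromatic rings that both carry oxygen on this carbon with a double bond to nitrogen, whereas the 2,6-dichlorophenyl group carries chlorine and no oxygen at all, and even this change of ring substituents gives no difference that can be told from repeat measurements of these three compounds. Nothing further is at hand that could explain this lack of a measurable difference.

Any step to compound 1 cannot be read, since compound 1 gives "not determined" (no result reported) in this series, so its ring adds nothing to the picture. Still open, going by these compounds, is whether a group of a different kind at this position, such as a ring bearing an amine or a carboxylic acid, or a longer chain in place of the ring, would move the number beyond the scatter.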